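The source may report more compounds than this note shows. Statements on the series, on what has been measured and on what is new or still open speak of the compounds shown alone.

Measured compounds: compound 1 `O=C(O)c1ccc2ccc(C(=O)c3ccccc3)c-2cc1` with 32.9%; compound 2 `NC(=O)c1ccc2ccc(C(=O)c3ccccc3)c-2cc1` with 18%; compound 3 `O=Cc1cc(-c2ccccc2)c2ccc(C(=O)O)ccc1-2` with 21.5%.

All three were tested in an assay on cells for displacement of a labelled ligand from Orexin receptor type 2 (Homo sapiens), read by scintillation counting, with stated times of 10 min and 90 min, tested at 10 uM; a lower number here means less inhibition, a higher number more inhibition at the concentration tested (going by the name of the read-out). The change amino in place of hydroxy on a carbonyl carbon gave a number 14.9 percentage points lower from compound 1 to compound 2 (beyond the scatter). Compound 3 has the same atoms as compound 1 joined differently; the difference between the two cores is not broken down here. Compound 4 `NC(=O)c1ccc2c(C=O)cc(-c3ccccc3)c-2cc1` is not yet measured. It differs from compound 3 by amino in place of hydroxy on a carbonyl carbon, the same change as from compound 1 to compound 2, at a place described in the same words. Since the earlier step was modest and beyond the scatter, a step of similar size is expected, giving a number 13.5 percentage points lower from compound 3 to compound 4 (beyond the scatter). Compound 4 is therefore estimated at 8%, with a likely range of -5% to 22%, resting on a single precedent.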

Compound 4, a percentage reported as inhibition, at one concentration (the size of the read-out at that concentration, not a potency): 16.7%
Compound 4: middle estimate off by 8.7 percentage points, on the low side; the measured number falls inside the stated range.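

On the core of compound 3, amino in place of hydroxy on a carbonyl carbon gave a number 4.8 percentage points lower from compound 3 to compound 4 (within the scatter) in this assay. Set beside the earlier step, the two do not differ by more than the scatter allows: the same change on two cores in this assay, a number 14.9 percentage points lower (beyond the scatter) from compound 1 to compound 2 and a number 4.8 percentage points lower (within the scatter) from compound 3 to compound 4, 10.1 percentage points apart, within the scatter of two such steps

Among the compounds shown here, the change can thus be carried between these two cores with no measurable difference in its size, but only one of the two steps stands clear of the scatter, so this does not show that the step is equal on both cores or that it holds on any other core.

The compounds shown leave open how a methyl ester or a nitrile would read in place of the carboxy group. They also leave open whether a substituted amide would follow carbamoyl on either core.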